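Swapping Ethynyl for Thiophen-3-yl on a Shared Core

The source may hold more compounds than are shown below. What is called first, only, known or untested is meant among the compounds shown, and "the series" means these compounds.

Compound 1 `C#Cc1cn([C@@H]2O[C@H](CO)[C@@H](O)[C@H]2O)c2ncnc(N(C)C)c12` gives 1320 nM in a functional assay on HepG2 cells (Homo sapiens) for antiproliferative activity, read by XTT assay, with a stated time of 72 h; a lower number here means a stronger inhibitor, a higher number a weaker inhibitor. Compound 2 `C#Cc1cn([C@@H]2O[C@H](CO)[C@@H](O)[C@H]2O)c2ncnc(NC)c12` reaches only a limit of the assay in this assay, recorded as > 15000 nM. Among the measured compounds shown here, the single measured step, an at least 11-fold higher number from compound 1 to compound 2 (1.05 log units; beyond the scatter), is therefore known only in direction, with compound 2 sitting at the limit of > 15000 nM in this assay, at which 1 of the 2 values shown sits. Compound 3 `CNc1ncnc2c1c(-c1ccsc1)cn2[C@@H]1O[C@H](CO)[C@@H](O)[C@H]1O` differs from compound 2 by thiophen-3-yl in place of ethynyl on an aromatic carbon. No measured step touches this position, so the numbers shown give no guide to its size or direction. Compound 3 is expected to stay weak, near 20000 nM. That estimate means a step that the limit leaves unreadable from compound 2 to compound 3, and the result may again be only a limit.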

Compound 3, half-maximal inhibitory concentration: > 20000 nM
Compound 3: no number, only a limit; the forecaster's own chance of this, stated with the estimate: 65%; the middle value sits exactly at the limit.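

Compound 2 and compound 3 are both recorded only as limits in this assay, not as numbers, and the step between them cannot be read. Going by these compounds, whether thiophen-3-yl in place of ethynyl changes the activity at all, and in which direction, stays open.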